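The compounds below may be only part of what the source reports. "The series", "measured", "known", "first", "only" and "open" are said of these compounds alone.

Series notes. Of the compounds shown here, two have been measured so far in an assay on cell membranes for inhibition of P2Y purinoceptor 1 (Meleagris gallopavo); a lower number here means a stronger inhibitor, a higher number a weaker inhibitor. Compound 1 `CNc1ncnc2c1ncn2CCC(COP(=O)(O)O)COP(=O)(O)O` gives 1600 nM in this assay. Compound 2 `CNc1ncnc2c1ncn2CC(COP(=O)(O)O)COP(=O)(O)O` gives 1090 nM in this assay. Compound 2 holds the lowest of the two numbers; its nearest neighbour is compound 1, and the two values lie within the usual scatter of each other, so no difference between them is read into the data.

Compound 3 `CNc1nc(Cl)nc2c1ncn2CC(COP(=O)(O)O)COP(=O)(O)O` is not yet measured. It differs from compound 2 in one place: chloro in place of hydrogen on an aromatic carbon. Among the measured compounds shown here, no step between measured compounds speaks to such a change, so there is no precedent here for its size or direction. With nothing in the series to anchor it, a modest move in this assay is expected, more likely toward a lower number than a higher one, though a result within the scatter is also plausible. For compound 3 the expected value in this assay is 500 nM, with a range of 150 nM to 1600 nM. That estimate means a step of a 2.2-fold lower number from compound 2 to compound 3 (0.34 log units; beyond the scatter) is expected.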

Compound 3, half-maximal inhibitory concentration: 480 nM
The estimate for compound 3 lay 1.0-fold (0.02 log units) above the measured number; the range from low to high includes it.
By their numbers in this assay, from the lowest: compound 3; then compounds 2 and 1 (each within the scatter of the next).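

In this assay, the aromatic carbon between two ring nitrogen atoms tolerates more than hydrogen: chloro at this position gives a 2.3-fold lower number from compound 2 to compound 3 (0.36 log units; beyond the scatter), a modest change but one that stands beyond the scatter. This position is therefore open to substitution, since a single added chlorine atom, with no ring, no hydrogen-bond donors or acceptors and no net charge, moves the number toward a stronger inhibitor while the rest of the structure stays the same. The compounds at hand offer nothing that accounts for this step, so the result stands as an observation without an explanation.

On these data alone, it remains open whether the step belongs to chloro specifically or extends to other groups on the same carbon, such as fluoro, bromo, methyl, methoxy or an amine, which would show how far the trend runs in size and kind. Also open, as far as these compounds go, is whether chloro at this position gives a similar step when paired with the longer chain of compound 1, or with a group other than methylamino on the same ring.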